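Fluoro Added to a Basic Ring: Expected Stability Gain

This account rests on a few compounds, and the source may have more. Where it says the series, first, only, none or still open, it means among the compounds named here.

Compound 1 `COc1cccc(-c2cn(C(=O)NCCCCc3ccccc3)c(=O)o2)c1` is the reference point. In an ADME assay on microsomes from liver (Mus musculus) for metabolic stability, read by LC-MS, using NADPH, tested at 4.6 uM (a higher number here means that the compound lasts longer, a lower number that the compound disappears faster), compound 1 gives 0.5 h. Compound 2 `COc1cc(-c2cn(C(=O)NCCCCc3ccccc3)c(=O)o2)ccc1F` carries fluoro in place of hydrogen on an aromatic carbon. Compound 2 reaches > 1 h in this assay, which is a limit of the assay rather than a number; this is the limit described in the limit of > 1 h in this assay, at which 1 of the 3 values shown sits. The step of an at least 2.0-fold higher number from compound 1 to compound 2 (0.30 log units; that floor lies within the scatter) is therefore only a floor. Compound 3 `CN1CCC(c2cccc(-c3cn(C(=O)NCCCCc4ccccc4)c(=O)o3)c2)CC1` carries 1-methylpiperidin-4-yl in place of methoxy on an aromatic carbon, and in this assay compound 3 gives 0.5 h, so the step of no change at the digits printed from compound 1 to compound 3 (within the scatter) shows no movement.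

Compound 4 `CN1CCC(c2cc(-c3cn(C(=O)NCCCCc4ccccc4)c(=O)o3)ccc2F)CC1` has not yet been measured in this assay. It differs from compound 3 by fluoro in place of hydrogen on an aromatic carbon. This is the same kind of change as in fluoro in place of hydrogen on an aromatic carbon, though the surroundings differ: there the fluoro sits ortho to a methoxy group, here ortho to a 1-methylpiperidin-4-yl group. Among the measured compounds shown here, a step of a 2.0-fold higher number from compound 3 to compound 4 (0.30 log units; within the scatter) is expected, set beside the measured at least 2.0-fold higher number from compound 1 to compound 2 (0.30 log units; that floor lies within the scatter), and it rests on compound 1, whose step an at least 2.0-fold higher number from compound 1 to compound 2 (0.30 log units; that floor lies within the scatter) is the only example of this change. Compound 4 is estimated at 1 h, between 0.5 h and 2 h.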

Compound 4, half-life: > 1 h
Compound 4: a limit, no number (the forecaster's own chance of this, stated with the estimate: 50%); the middle value sits exactly at the limit.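

In this assay compound 4 gives > 1 h, which is a limit of the assay and not a number. The fluoro change therefore has a size known only as a floor, an at least 2.0-fold higher number from compound 3 to compound 4 (0.30 log units; that floor lies within the scatter), and the step between compound 2 and compound 4 cannot be read. Both cores fit with the change carrying over from one to the other, but the results do not show that it has the same size on each, or that either step lies beyond the scatter: the same change on two cores in this assay, an at least 2.0-fold higher number (0.30 log units; that floor lies within the scatter) from compound 1 to compound 2 and an at least 2.0-fold higher number (0.30 log units; that floor lies within the scatter) from compound 3 to compound 4; the limit leaves it open whether they differ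

From the compounds shown here alone, the true size of the fluoro step on either core stays open: the limit of > 1 h in this assay, at which 2 of the 4 values shown sit. Also open is whether the step would look the same with a carboxylic acid in place of the 1-methylpiperidin-4-yl group, or with chloro in place of the fluoro.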